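A configuration change among the nitrile compounds

The source may hold more compounds than are shown below. What is called first, only, known or untested is meant among the compounds shown, and "the series" means these compounds.

So far two compounds have numbers. In an ADME assay on MDCK-II cells (Canis lupus familiaris) for permeability (on this read-out lower numbers stand for lower permeability and higher numbers for higher permeability), compound 1 (`CC(=O)N1CC(CC#N)(n2cc(-c3nc(-c4cnn(C)c4)cn4nccc34)cn2)C1`) gives 4 10^-6 cm/s as its reading. Compound 2 (`Cn1ccc(-c2cn3nccc3c(-c3cnn([C@]4(CC#N)C[C@@H](C#N)C4)c3)n2)n1`) gives 20 10^-6 cm/s as its reading, the higher of the two numbers, and the gap between them lies beyond the scatter.

Compound 3 (`Cn1ccc(-c2cn3nccc3c(-c3cnn([C@]4(CC#N)C[C@H](C#N)C4)c3)n2)n1`) is not yet measured. Its difference from compound 2 is this: the two compounds have the same atoms and bonds and differ only in configuration as drawn: 2 of 2 stereo elements differ (all stereocentres are inverted: mirror images); a stereocentre at a saturated ring carbon is drawn r in compound 2 and s in compound 3; a stereocentre at a saturated ring carbon is drawn r in compound 2 and s in compound 3. Nothing leaves and nothing enters, and both stereocentres at saturated ring carbons are inverted, so the two compounds are drawn as mirror images.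

Going by the values given here, no measured pair shows a change of configuration alone, so compound 2 at 20 10^-6 cm/s is the only anchor for the expectation in this assay here. The expected no change at the digits printed from compound 2 to compound 3 (within the scatter) is none beyond the scatter, with no direction favoured. Compound 3 is estimated at 20 10^-6 cm/s (expected range 10 10^-6 cm/s to 38 10^-6 cm/s) on this read-out.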

Compound 3, apparent permeability: 14 10^-6 cm/s
Compound 3: middle estimate off by 1.4-fold (0.15 log units), on the high side; low and high end bracket the measured number.
By their numbers in this assay, from the lowest: compound 1; then compounds 3 and 2 (each within the scatter of the next).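

In this assay the series now holds its first pair that tests configuration alone, and the step reads a 1.4-fold lower number from compound 2 to compound 3 (0.15 log units; within the scatter). Inverting both stereocentres at saturated ring carbons therefore gives no separation beyond the scatter on this read-out, so this mirror-image pair offers no basis for preferring either drawn configuration. The comparison is clean on one structural point: the fact that compounds 2 and 3 differ only in the configuration as drawn.

Still open is what happens when only one of the two stereocentres is inverted, since the pair shown changes both at once. Also open is how this read-out responds when a carboxylic acid or an amine takes the place of one of the nitriles, as no single-place step among the compounds shown touches a group.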